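Swapping Ethylamino for Dimethylamino on the Shared Core

This account rests on a few compounds, and the source may have more. Where it says the series, first, only, none or still open, it means among the compounds named here.

For the measured compounds named here, in a functional assay on HCT-116 cells (Homo sapiens) for inhibition, read by luminescence and resazurin assay, with a stated time of 3 days (on this read-out higher numbers stand for weaker inhibition and lower numbers for stronger inhibition), compound 2 `CCNc1nc(NCc2ccc(C(=O)N[C@H]3C[C@@H]3c3ccccc3)cc2)c2cc(C)ccc2n1` gives 1700 nM, the only plain number measured so far. Compound 1 `CNc1nc2ccccc2c(NCc2ccc(NC(=O)c3ccc(F)cc3)cc2)c1C#N` reaches only the limit of this assay, > 20000 nM, which is a limit and not a number (the limit of > 20000 nM in this assay, at which 1 of the 2 values shown sits). Compound 3 `Cc1ccc2nc(N(C)C)nc(NCc3ccc(C(=O)N[C@H]4C[C@@H]4c4ccccc4)cc3)c2c1` differs from compound 2 by dimethylamino in place of ethylamino on an aromatic carbon. Going by the values given here, no step between two measured compounds is known, so this change is untested here; a small shift is expected, if any, at the edge of the usual scatter. Compound 3 is expected to give 3000 nM, within 1000 nM to 9000 nM. That expectation amounts to a step of a 1.8-fold higher number from compound 2 to compound 3 (0.25 log units; within the scatter), slightly toward weaker inhibition.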

Compound 3, half-maximal inhibitory concentration: 1300 nM
The estimate for compound 3 lay 2.3-fold (0.36 log units) above the measured number; the measured number falls inside the stated range.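

For the compounds shown here, this is the first comparison at this position: in this assay, dimethylamino in place of ethylamino gives a 1.3-fold lower number from compound 2 to compound 3 (0.12 log units; within the scatter), so the two compounds cannot be told apart. Ethylamino counts one hydrogen-bond donor and dimethylamino none, so in this one pair, losing that donor makes no readable difference. Nothing shown here gives a cause for this result.

On these data alone, how a plain amine, a longer chain such as butylamino or a ring such as morpholine would read on this same carbon stays open. One pair cannot show whether other groups here would also leave the number unchanged.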